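Chain Lengthening and Bromine Removal on a Thiophene Sulfonamide

This account rests on a few compounds, and the source may have more. Where it says the series, first, only, none or still open, it means among the compounds named here.

Compound 1 `CCN(C/C=C/C#CC(C)(C)C)Cc1cccc(OCCN(C)S(=O)(=O)c2cccs2)c1` gives 60 nM in a functional assay on HepG2 cells for inhibition of squalene monooxygenase (Homo sapiens); on this read-out lower numbers stand for stronger inhibition and higher numbers for weaker inhibition.
Compound 2 `CCN(C/C=C/C#CC(C)(C)C)Cc1cccc(OCCN(C)S(=O)(=O)c2ccc(Br)s2)c1` gives 390 nM in this assay.
Compound 3 `CCN(C/C=C/C#CC(C)(C)C)Cc1cccc(OCCN(C)S(=O)(=O)c2cc(Br)cs2)c1` gives 300 nM in this assay.

Compound 3 stands second highest of the three numbers; the steps that lead to it are a 1.3-fold lower number from compound 2 to compound 3 (0.11 log units; within the scatter) and a 5.0-fold higher number from compound 1 to compound 3 (0.70 log units; beyond the scatter). Compound 4 `CCN(C/C=C/C#CC(C)(C)C)Cc1cccc(OCCCN(C)S(=O)(=O)c2cccs2)c1` differs from compound 3 by a group of 11 heavy atoms (6 carbon, 1 nitrogen, 2 oxygen, 2 sulfur; one five-membered aromatic ring with 1 hetero atom) in place of a group of 11 heavy atoms (5 carbon, 1 nitrogen, 2 oxygen, 2 sulfur, 1 bromine; one five-membered aromatic ring with 1 hetero atom), on a saturated chain carbon, two bonds along the chain from an oxygen on an aromatic ring. Of the measured steps, only the bromine change bears on it: removing bromine, as from compound 3 to compound 1, gave a step of that modest size downward. Among the compounds with values here, no measured step covers the longer chain. Compound 4 is therefore expected to move by about a 3.5-fold lower number from compound 3 to compound 4 (0.55 log units; beyond the scatter) in this assay. Compound 4 is estimated at 85 nM, with a range from 30 nM to 260 nM.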

Compound 4, half-maximal inhibitory concentration: 6400 nM
Compound 4: the middle estimate sits 75-fold (1.88 log units) below what was measured; measured number above the stated range.
By their numbers in this assay, from the lowest: compound 1; then compounds 3 and 2 (each within the scatter of the next); then compound 4.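

In this assay, the longer chain alone, (methyl((thiophen-2-yl)sulfonyl)amino)methyl in place of methyl((thiophen-2-yl)sulfonyl)amino, gives a 110-fold higher number from compound 1 to compound 4 (2.03 log units; beyond the scatter), so this position responds far more strongly to this change than the thiophene did to bromine. The two brominated compounds also keep much lower numbers than the longer-chain compound, with a 21-fold higher number from compound 3 to compound 4 (1.33 log units; beyond the scatter) and a 16-fold higher number from compound 2 to compound 4 (1.22 log units; beyond the scatter), so the absence of bromine does not offset the longer chain. Nothing available explains this loss.

From the compounds shown here alone, it remains open whether a still longer chain, or a hydroxyl group on this chain, would behave differently, and whether bromine on the thiophene would have the same effect on the longer chain.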